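Ring methyl next to the sulfamoylamino group

The source may report more compounds than this note shows. Statements on the series, on what has been measured and on what is new or still open speak of the compounds shown alone.

In a functional assay on the whole organism for inhibition, with Mus musculus as the target (a lower number here means that less compound is needed, a higher number that more compound is needed for the effect), compound 3 `CCN1CCCC1CNC(=O)c1cc(NS(=O)(=O)NC)ccc1OC` reaches only the limit > 50 mg/kg. Compound 3 is the one that sits at the limit of > 50 mg/kg in this assay, at which 1 of the 3 values shown sits. Among the measured compounds shown here, compound 1 `CCN1CCCC1CNC(=O)c1cc(NS(=O)(=O)N(C)C)c(C)cc1OC` gives 13.3 mg/kg in this assay and compound 2 `CCN1CCCC1CNC(=O)c1cc(NS(C)(=O)=O)c(C)cc1OC` gives 35.6 mg/kg in this assay; the one measured step, a 2.7-fold higher number from compound 1 to compound 2 (0.43 log units; beyond the scatter), concerns the sulfonyl substituent and not the ring. Compound 4 `CCN1CCCC1CNC(=O)c1cc(NS(=O)(=O)NC)c(C)cc1OC` differs from compound 3 by methyl in place of hydrogen on an aromatic carbon. For the measured compounds named here, no measured step covers this ring change; compounds 1 and 2, which both carry the methyl, give numbers, while compound 3 without it gives a limit. Compound 4 is therefore expected to fall among the numbered values, an estimated 25 mg/kg (range 10 mg/kg to 60 mg/kg), which means an expected step of an at least 2.0-fold lower number from compound 3 to compound 4 (0.30 log units; that floor lies within the scatter).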

Compound 4, dose for half-maximal effect: > 50 mg/kg
Compound 4 gave a limit, no number (the forecaster's own chance of this, stated with the estimate: 30%); at least 2.0-fold (0.30 log units) between middle value and limit.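

With the methyl ortho to a (methylsulfamoyl)amino group, compound 4 still gives only a limit in this assay, so this ring change alone yields no number and the step from compound 3 cannot be read: the limit of > 50 mg/kg in this assay, at which 2 of the 4 values shown sit.

The sulfonamide nitrogen now stands out, with hydrogen in place of methyl giving an at least 3.7-fold higher number from compound 1 to compound 4 (0.57 log units; beyond the scatter). Against the methyl on sulfonyl sulfur, the change to methylamino gives an at least 1.4-fold higher number from compound 2 to compound 4 (0.14 log units; that floor lies within the scatter), which says little.

Open, going by these compounds, is whether the ring methyl matters at all with dimethylamino on the sulfonyl sulfur. Also open, on these data alone, is whether a chlorine or an ethyl on this aromatic carbon would give a number.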